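The compounds below may be only part of what the source reports. "The series", "measured", "known", "first", "only" and "open" are said of these compounds alone.

Measured compounds in a functional assay on ACHN cells (Homo sapiens) for inhibition, read by sulforhodamine B assay, with a stated time of 48 h, tested at 10 uM; on this read-out lower numbers stand for a stronger effect and higher numbers for a weaker effect at the one concentration tested:
- compound 1, `COc1cc(Cl)cc(-c2nn(-c3cccc(NC(=O)c4cccc(C(F)(F)F)c4)c3)cc2-c2ccncc2)c1`: 48.1%
- compound 2, `O=C(Nc1cccc(-n2cc(-c3ccncc3)c(-c3cc(O)cc(Cl)c3)n2)c1)c1cc(C(F)(F)F)cc(C(F)(F)F)c1`: 37.7%

Compound 2 holds the lowest of the two numbers in this assay. Its nearest neighbour is compound 1, whose value sits higher by a gap beyond the scatter. Among the compounds with values here, the two compounds differ in more than one place, so their values show only that the pair is separated, not what any single group contributes.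

The next compound, compound 3, `COc1cc(Cl)cc(-c2nn(-c3cccc(NC(=O)c4cc(C(F)(F)F)cc(C(F)(F)F)c4)c3)cc2-c2ccncc2)c1`, is built from compound 2 by one change, (methyl in place of hydrogen on an oxygen on an aromatic ring). Within the data shown here, no measured pair isolates this change, so no measured step can be quoted for it; the expectation rests only on the value of compound 2 and on the small size of the change. The step from compound 2 to compound 3 in this assay is expected to be small, within the scatter, with a slight lean towards a higher number, which the estimate a number 5.3 percentage points higher from compound 2 to compound 3 (within the scatter) reflects. For compound 3 in this assay the estimate is 43%, with a range from 29% to 58%.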

Compound 3, a percentage reported as activity, at one concentration (the size of the read-out at that concentration, not a potency): 58.2%
Beside the measured number, compound 3's estimate is 15.2 percentage points below it, outside the stated range (above it).
By their numbers in this assay, from the lowest: compound 2; then compound 1; then compound 3.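

In this assay, the position on the 3-chloro-5-hydroxyphenyl group proves sensitive to a single added methyl: going from hydroxy to methoxy gives a number 20.5 percentage points higher from compound 2 to compound 3 (beyond the scatter), so the free hydroxy goes with the stronger effect at the one concentration tested in this pair. The other end of compound 3 also responds, since trifluoromethyl in place of hydrogen on an aromatic carbon gives a number 10.1 percentage points higher from compound 1 to compound 3 (beyond the scatter), and with the methoxy group present the extra trifluoromethyl therefore goes with a weaker effect. No measurement here explains either step.

From the compounds shown here alone, the trifluoromethyl step has been read only with the methoxy group present, so its direction and size with the hydroxy group in place remain open. Going by these compounds, it also remains open how this position would read with an amine or a longer ethoxy chain in place of the hydroxy, and thus whether the step seen here reflects the methyl alone or extends to other groups at this oxygen-bearing place.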